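The source may report more compounds than this note shows. Statements on the series, on what has been measured and on what is new or still open speak of the compounds shown alone.

Measured compounds in a functional assay on CHO cells for agonist activity at Free fatty acid receptor 2 (Homo sapiens), read by cAMP accumulation; on this read-out lower numbers stand for smaller maximal responses and higher numbers for larger maximal responses:
compound 1, `CC(C)[C@H](C(=O)NC(C)(C)C)c1ccc(Cl)cc1`, compound 1 gives < 30%
compound 2, `CC(C)C(C(=O)Nc1ncccn1)c1ccc(Cl)cc1`, compound 2 gives 50%
compound 3, `CC(C)C(C(=O)Nc1cnccn1)c1ccc(Cl)cc1`, compound 3 gives 115%

Compound 1 does not stand at a number in this assay; its value is a limit of the measurement, as one of the three readings does (the limit of < 30% in this assay, at which 1 of the 3 values shown sits). The unmeasured compound 4, `CC(C)[C@H](C(=O)Nc1ncns1)c1ccc(Cl)cc1`, differs from compound 1 in one place: 1,2,4-thiadiazol-5-yl in place of tert-butyl on an amide-type nitrogen. Going by the values given here, no measured step exchanges tert-butyl for a ring on this nitrogen, so the step from compound 1 to compound 4 has no direct precedent. Among the compounds with values here, the one measured step on this nitrogen, a number 65 percentage points higher from compound 2 to compound 3 (beyond the scatter), shows that two heteroaryl groups of this kind can lie far apart, with compound 2 at its value and compound 3 well above it. A 1,2,4-thiadiazol-5-yl group entering in place of tert-butyl is therefore expected to raise the maximal response beyond the scatter, with the size open. Compound 4 is estimated at 70%, between 30% and 115%, an expected step of a number at least 40 percentage points higher from compound 1 to compound 4 (beyond the scatter).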

Compound 4, largest response reached (reported as efficacy), in percent of the reference or control that the assay uses: 99%
Compound 4: the middle estimate sits 29 percentage points below what was measured; measured number inside the range.
By their numbers in this assay, from the lowest: compound 2; then compound 4; then compound 3. At a limit, below all of these: compound 1.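

Placing 1,2,4-thiadiazol-5-yl instead of tert-butyl on the amide-type nitrogen gives, in this assay, a number at least 69 percentage points higher from compound 1 to compound 4 (beyond the scatter). The earlier step at this nitrogen only exchanged one heteroaryl group for another, whereas this one replaces an open-chain group with no ring by a five-membered aromatic ring and shows that this exchange can carry a large rise in maximal response. Going by these compounds, compound 1 stands at a limit and not at a number, so the step gives only a floor and its full size remains unknown: the limit of < 30% in this assay, at which 1 of the 4 values shown sits.

The compounds shown do not tell whether the rise depends on the ring nitrogens, the sulfur or the ring itself, which a phenyl or thiazol-2-yl group on this nitrogen could separate. They also leave open how a change elsewhere in the shared core, such as a methoxy group in place of the chlorine, would alter the response.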